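A few compounds are considered here, and "the series" means these few. Any claim that something is new, unique, unknown or untested is made for them only; others in the source may bear on it.

Three close relatives share one core and have been tested in a functional assay on RXF 393 cells (Homo sapiens) for inhibition, read by sulforhodamine B assay, with a stated time of 48 h; a lower number here means a stronger inhibitor of growth, a higher number a weaker inhibitor of growth. Compound 1 `O=C(Nc1cccc(-n2cc(-c3ccncc3)c(-c3ccc(Cl)c(O)c3)n2)c1)Nc1ccc(Cl)c(Cl)c1` gives 1000 nM. Compound 2 `COc1cc(-c2nn(-c3cccc(NC(=O)c4cccc(C(F)(F)F)c4)c3)cc2-c2ccncc2)ccc1Cl` gives 811 nM. Compound 3 `O=C(Nc1cccc(-n2cc(-c3ccncc3)c(-c3ccc(Cl)c(O)c3)n2)c1)Nc1cc(C(F)(F)F)cc(C(F)(F)F)c1` gives 937 nM. The three numbers sit so close together that the gaps between them fall inside the usual scatter of repeated measurements, so none of the three can be called a stronger or weaker growth inhibitor than the others; compound 2 simply sits at the low end of this narrow spread, with compound 3 and compound 1 both within the scatter of it.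

The step of interest leads from compound 2 to compound 4 `COc1cc(-c2nn(-c3cccc(NC(=O)c4ccccc4)c3)cc2-c2ccncc2)ccc1Cl`, which is not yet measured. The change is small: hydrogen in place of trifluoromethyl on an aromatic carbon. Among the measured compounds shown here, no measured pair in this set shows the effect of such a change, so there is no direct guide. A shift of this kind is expected to move the number at most a little, if anything toward a weaker inhibitor, and the step from compound 2 to compound 4 is estimated as a 1.5-fold higher number from compound 2 to compound 4 (0.17 log units; within the scatter). Compound 4 is therefore expected to give about 1200 nM in this assay, within a range from 500 nM to 3000 nM.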

Compound 4, concentration for 50% growth inhibition: 646 nM
Beside the measured number, compound 4's estimate is 1.9-fold (0.27 log units) above it; low and high end bracket the measured number.
By their numbers in this assay, from the lowest: compounds 4, 2, 3 and 1 (each within the scatter of the next).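

Among the compounds shown here, this is the first direct look at this position: in this assay, putting hydrogen in place of trifluoromethyl on this aromatic carbon gives a 1.3-fold lower number from compound 2 to compound 4 (0.10 log units; within the scatter). The 3-(trifluoromethyl)phenyl group can therefore give way to plain phenyl with no difference that this assay can tell apart from ordinary repeat variation, so the trifluoromethyl group is not needed to keep growth inhibition at this level. Nothing available here explains this result.

The compounds shown leave open whether another group on the same aromatic carbon, such as an amine, a carboxylic acid or a longer carbon chain, would move the number beyond the scatter. They also leave open whether hydrogen in place of a trifluoromethyl group on compound 3 would read the same way.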